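The source may report more compounds than this note shows. Statements on the series, on what has been measured and on what is new or still open speak of the compounds shown alone.

The two measured compounds share one core and differ only at a single aromatic carbon. Compound 1 `Nc1nn(C(=O)Nc2ccc(Cc3ccccc3)cc2)c2ccccc12` gives 41500 nM in a functional assay on SW-620 cells (Homo sapiens) for antiproliferative activity, read by sulforhodamine B assay, with a stated time of 48 h; a higher number here means a weaker inhibitor of growth, a lower number a stronger inhibitor of growth. Compound 2 `Nc1nn(C(=O)Nc2ccc(Cc3ccccc3)cc2)c2ccc(Cl)cc12` gives 76500 nM in the same assay, the higher of the two numbers; its nearest neighbour is compound 1, and the step of a 1.8-fold higher number from compound 1 to compound 2 (0.27 log units; within the scatter) is within the scatter, so the two compounds cannot be told apart on these data.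

Compound 3 `Nc1ccc2c(c1)c(N)nn2C(=O)Nc1ccc(Cc2ccccc2)cc1` has not yet been measured. It differs from compound 2 in one place: amino in place of chloro on an aromatic carbon. Among the measured compounds shown here, the only measured step, from hydrogen to chloro at this position, bears on it indirectly and was within the scatter. For the measured compounds named here, no measured step shows what an amino group does here, so the only guidance is that a small change at this carbon has so far moved the number by less than the scatter. The expectation for compound 3 is therefore a step of a 1.5-fold lower number from compound 2 to compound 3 (0.18 log units; within the scatter) of no clear size beyond the scatter. Compound 3 is estimated at 50000 nM, with a range from 15000 nM to 160000 nM.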

Compound 3, concentration for total growth inhibition: 18700 nM
The estimate for compound 3 lay 2.7-fold (0.43 log units) above the measured number; the range from low to high includes it.
By their numbers in this assay, from the lowest: compound 3; then compounds 1 and 2 (each within the scatter of the next).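

At this aromatic carbon the number can move beyond the scatter: in this assay, amino in place of chloro gives a 4.1-fold lower number from compound 2 to compound 3 (0.61 log units; beyond the scatter), and amino in place of hydrogen gives a 2.2-fold lower number from compound 1 to compound 3 (0.35 log units; beyond the scatter), both modest in size. Hydrogen and chloro could not be told apart here, whereas amino stands apart from each of them on the side of stronger growth inhibition, so this carbon is not indifferent to the group it carries. The computed change shows that amino brings 1 hydrogen-bond donor and 1 hydrogen-bond acceptor where chloro has none, but that is only a count, and nothing shown here explains the difference in activity.

The compounds shown leave open whether the gain belongs to the amino group alone or would also appear with a close relative such as hydroxyl, methylamino or acetylamino on the same carbon. They also leave open whether amino would give a similar step on another carbon of this ring, and whether the step would hold in other cell lines.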